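A few compounds are considered here, and "the series" means these few. Any claim that something is new, unique, unknown or untested is made for them only; others in the source may bear on it.

In an ADME assay on HEL cells (Homo sapiens) for cytotoxicity, read by microscopy, with a stated time of 3 days (on this read-out higher numbers stand for lower toxicity in this test and lower numbers for higher toxicity in this test), compound 1 `CCOC(=O)C1(Cc2ccccc2)CN(c2ccccc2)Cc2nnn(Cc3cccc(F)c3)c21` reaches only a limit of the assay, >= 100000 nM. Compound 2 `CCOC(=O)C1(Cc2ccccc2)CN(c2ccccc2)Cc2nnn(Cc3ccccc3Cl)c21` differs from compound 1 by 2-chlorophenyl in place of 3-fluorophenyl on a saturated chain carbon bound to an aromatic nitrogen. In this assay compound 2 likewise gives only a limit, > 100000 nM. The step that the two limits leave unreadable from compound 1 to compound 2 therefore cannot be read, because both values sit at the top of the tested range, one at the limit of > 100000 nM in this assay, at which 1 of the 2 values shown sits, and the other at the limit of >= 100000 nM in this assay, at which 1 of the 2 values shown sits. Compound 3 `CCCCCCCCn1nnc2c1C(Cc1ccccc1)(C(=O)OCC)CN(c1ccccc1)C2` is not yet measured. It differs from compound 1 by heptyl in place of 3-fluorophenyl on a saturated chain carbon bound to an aromatic nitrogen. The single measured step, which also exchanges the group on that carbon, fixes no size, so the shown pairs give no direction for this new change. Compound 3 is therefore expected to remain near the same limit, with an estimated step of a number no higher from compound 1 to compound 3 (the limit leaves the size open). For compound 3 the estimate is 100000 nM, with a range from 30000 nM to 200000 nM.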

Compound 3, minimum cytotoxic concentration: >= 20000 nM
Compound 3: a limit, no number (the forecaster's own chance of this, stated with the estimate: 70%); the middle value does not contradict the limit.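

In this assay compound 3 gives only a limit, >= 20000 nM. Neither the step from compound 1 to compound 3 nor the step from compound 2 to compound 3 can be read, as all the values shown are limits. The compounds shown leave open how the heptyl, 3-fluorophenyl and 2-chlorophenyl groups compare in cytotoxicity on HEL cells.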